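The source may hold more compounds than are shown below. What is called first, only, known or untested is meant among the compounds shown, and "the series" means these compounds.

Three diaryl ureas from one series have been measured in a functional assay on A2780 cells (Homo sapiens) for inhibition, with a stated time of 72 h; a higher number here means a weaker inhibitor, a lower number a stronger inhibitor. Compound 1 `CC1(C)CC(C)(C)c2cc(NC(=O)Nc3ccc(C(F)(F)F)cc3)ccc2O1` gives 3600 nM. Compound 2 `CCC1(CC)CC(CC)(CC)c2cc(NC(=O)Nc3ccc(OC(F)(F)F)cc3)ccc2O1` gives 3000 nM. Compound 3 `CC1(C)CC(C)(C)c2cc(NC(=O)Nc3ccc(OC(F)(F)F)cc3)ccc2O1` gives 4560 nM. Going by the values given here, the three numbers all lie within the usual scatter of one another, so no compound can be called the strongest or the weakest of the set.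

Compound 1 and compound 3 share a core and differ only in one place: trifluoromethyl in place of trifluoromethoxy on an aromatic carbon. This change gave a 1.3-fold lower number from compound 3 to compound 1 (0.10 log units; within the scatter).

Among the compounds with values here, compound 2 and compound 3 differ in their cores, and that difference is not broken down here; their values show only that the two numbers lie close together.

Compound 4 `CCC1(CC)CC(CC)(CC)c2cc(NC(=O)Nc3ccc(C(F)(F)F)cc3)ccc2O1` has not yet been measured. It stands to compound 2 as compound 1 stands to compound 3, since (trifluoromethyl in place of trifluoromethoxy on an aromatic carbon). The place of the change is described in the same words for both pairs, so this is the same change made on the core of compound 2 rather than on the core of compound 3.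

Because the earlier step, a 1.3-fold lower number from compound 3 to compound 1 (0.10 log units; within the scatter), was small and within the scatter, compound 4 is expected to show a 1.2-fold lower number from compound 2 to compound 4 (0.08 log units; within the scatter) in this assay, a step of about the same size. Compound 4 is therefore estimated at 2500 nM, with a likely range from 1200 nM to 5500 nM; this rests on a single prior instance of the change and carries the uncertainty of that small base.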

Compound 4, half-maximal inhibitory concentration: 2000 nM
Estimate against measurement, compound 4: 1.3-fold (0.10 log units) above; measured number inside the range.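

On the core of compound 2, putting trifluoromethyl in place of trifluoromethoxy gave a 1.5-fold lower number from compound 2 to compound 4 (0.18 log units; within the scatter) in this assay, so the change from 4-(trifluoromethoxy)phenyl to 4-(trifluoromethyl)phenyl again moved the number by no more than the usual scatter. Set beside the earlier instance of the same change on the core of compound 3, the new step does not differ from it: the same change on two cores in this assay, a 1.3-fold lower number (0.10 log units; within the scatter) from compound 3 to compound 1 and a 1.5-fold lower number (0.18 log units; within the scatter) from compound 2 to compound 4, 1.2-fold (0.07 log units) apart, within the scatter of two such steps. This shows that, on these two cores, the change carries over without any difference that can be told apart in this assay, but it does not show that either group gives the stronger inhibitor, since each step taken alone stays within the scatter, and two cores are too few to say how the change would behave on a third.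

The compounds shown leave open how a nitrile, a chlorine atom or a carboxylic acid would behave on that aromatic carbon in place of these two groups, and whether the step would stay this small with propyl chains on the core. They also leave open whether the same holds in any setting other than this assay.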